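Carbamoyl to ethyl(methyl)carbamoyl on the methoxybenzyl analog

The source may hold more compounds than are shown below. What is called first, only, known or untested is meant among the compounds shown, and "the series" means these compounds.

Compound 3 `COc1ccc(Cn2cc(CSC(=S)N3CCN(C(N)=O)CC3)nn2)cc1` gives only a limit, > 128000 nM, in a functional assay on EC9706 cells (Homo sapiens) for cytotoxicity, read by MTT assay, with a stated time of 72 h; on this read-out lower numbers stand for stronger inhibition and higher numbers for weaker inhibition. Compound 3 thus sits at the limit of > 128000 nM in this assay, at which 1 of the 3 values shown sits, and has no number to anchor a step. Compound 4 `CCN(C)C(=O)N1CCN(C(=S)SCc2cn(Cc3ccc(OC)cc3)nn2)CC1` differs from it by ethyl(methyl)amino in place of amino on a carbonyl carbon. Among the compounds with values here, the one measured step, between compound 1 `CCN(C)C(=O)N1CCN(C(=S)SCc2cn(Cc3ccc(F)cc3)nn2)CC1` with 14300 nM and compound 2 `CCN(C)C(=O)N1CCN(C(=S)SCc2cn(Cc3ccc(C)cc3)nn2)CC1` with 70600 nM, reads a 4.9-fold higher number from compound 1 to compound 2 (0.69 log units; beyond the scatter); it concerns the aromatic carbon, not the carbonyl, so no measured step covers the carbamoyl change. Compound 4 shares the ethyl(methyl)carbamoyl of compounds 1 and 2, and its number is expected to fall near theirs. For compound 4 the estimate is 50000 nM, with a range of 15000 nM to 160000 nM. The expected step is an at least 2.5-fold lower number from compound 3 to compound 4 (0.40 log units; beyond the scatter).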

Compound 4, half-maximal inhibitory concentration: > 128000 nM
Compound 4: no number, only a limit; the forecaster's own chance of this, stated with the estimate: 30%; at least 2.5-fold (0.40 log units) between middle value and limit.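

With ethyl(methyl)carbamoyl in place of carbamoyl, the methoxy analog stays at the limit of the assay, and the step from compound 3 to compound 4 cannot be read: the limit of > 128000 nM in this assay, at which 2 of the 4 values shown sit. On the aromatic carbon, methoxy in place of fluoro gives an at least 8.9-fold higher number from compound 1 to compound 4 (0.95 log units; beyond the scatter), while methoxy in place of methyl gives an at least 1.8-fold higher number from compound 2 to compound 4 (0.25 log units; that floor lies within the scatter). Only the change from fluoro is therefore established as beyond the scatter.

On these data alone, the effect of ethyl(methyl)carbamoyl against carbamoyl remains open. Also open, as far as these compounds go, is how a chloro group or an amine on that aromatic carbon would read against fluoro.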